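Amide nitrogen substituent: from compound 2 to compound 3

The source may report more compounds than this note shows. Statements on the series, on what has been measured and on what is new or still open speak of the compounds shown alone.

Two members of the series have readings in an assay on CHO T-rex cells for antagonist activity at transient receptor potential cation channel subfamily M member 8 (Homo sapiens), read by calcium flux, with a stated time of 20 min; a lower number here means a stronger inhibitor, a higher number a weaker inhibitor. Compound 1 `C[C@H](c1ccc(F)cc1)N(Cc1cccc(C(=O)O)c1)C(=O)c1cc2ccccc2nn1` gives 340 nM, a numeric value. Compound 2 `O=C(O)c1cccc(CN(Cc2ccc(F)cc2)C(=O)c2cnc3ccccc3c2)c1` returns only the limit > 9350 nM in this assay, so for compound 2 no number is known, only that it sits at the limit of > 9350 nM in this assay, at which 1 of the 2 values shown sits. Compound 2 therefore stands at the weak end of what the two readings show, while compound 1 is the one fixed point with a measured potency.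

Compound 3 `COc1ccc(C(C)N(Cc2cccc(C(=O)O)c2)C(=O)c2cnc3ccccc3c2)cc1` is not yet measured. It differs from compound 2 in one place: 1-(4-methoxyphenyl)ethyl in place of 4-fluorobenzyl on an amide-type nitrogen whose other neighbours are the carbonyl carbon and a saturated chain carbon. For the measured compounds named here, no measured step of this kind is available, so the size of the change cannot be read off the data. With compound 2 at a limit, any shift is expected to run toward stronger inhibition or to stay within the scatter, and the expected step is an at least 3.1-fold lower number from compound 2 to compound 3 (0.49 log units; beyond the scatter). For compound 3 the estimate is 3000 nM, in the range 600 nM to 15000 nM, with a real chance that this assay again reports only a limit.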

Compound 3, half-maximal inhibitory concentration: 6100 nM
Beside the measured number, compound 3's estimate is 2.0-fold (0.31 log units) below it, within the range that was stated.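

On the amide-type nitrogen, 1-(4-methoxyphenyl)ethyl in place of 4-fluorobenzyl gives this core its first numeric reading in this assay, with compound 3 at 6100 nM. The change can be read only as an at least 1.5-fold lower number from compound 2 to compound 3 (0.18 log units; that floor lies within the scatter), so the data do not establish a shift beyond the scatter, and compound 2 is a limit rather than a number, which leaves the step a floor without a fixed size: the limit of > 9350 nM in this assay, at which 1 of the 3 values shown sits. The swap also alters two features at once, adding a methyl branch on the saturated chain carbon and replacing the ring fluorine with methoxy, so any effect belongs to the pair of changes and cannot be assigned to either one.

A 4-methoxybenzyl group on the same nitrogen would separate the ring substituent from the branch, a contrast the compounds shown do not provide. Compound 3 is also drawn without a set configuration at its branched carbon, so the readings leave open how its two mirror-image forms compare in this assay.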